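Chlorine for Fluorine on the Benzyl Arm

The source may hold more compounds than are shown below. What is called first, only, known or untested is meant among the compounds shown, and "the series" means these compounds.

Among the compounds with values here, compound 2 `CC(C)(C)c1cc(/C=C/C(=O)NCCC2CCN(Cc3ccc(F)cc3F)CC2)cc(C(C)(C)C)c1O` gives 12500 nM in an assay on isolated protein for inhibition of Amine oxidase [flavin-containing] B (Homo sapiens), read by fluorescence, with stated times of 15 min and 20 min (on this read-out higher numbers stand for weaker inhibition and lower numbers for stronger inhibition), the highest of the two numbers measured so far. Within the data shown here, its nearest neighbour is compound 1 `CC(C)(C)c1cc(/C=C/C(=O)NCCC2CCN(Cc3cccc(F)c3)CC2)cc(C(C)(C)C)c1O`, which in this assay gives 6500 nM; the step between them, a 1.9-fold higher number from compound 1 to compound 2 (0.28 log units; within the scatter), is the only measured step in the set. Compound 3 `CC(C)(C)c1cc(/C=C/C(=O)NCCC2CCN(Cc3cccc(Cl)c3)CC2)cc(C(C)(C)C)c1O` has not been measured; it differs from compound 2 by 3-chlorophenyl in place of 2,4-difluorophenyl on a saturated chain carbon bound to an amine nitrogen in a ring. Among the measured compounds shown here, the one measured step bears directly on this change, since it altered the same group at the same place and stayed within the scatter. Compound 3 bears a 3-chlorophenyl group, a single halogen on the ring as in the 3-fluorophenyl of compound 1, so a number near that of compound 1 is expected and no step beyond the scatter. The expected step is a 2.1-fold lower number from compound 2 to compound 3 (0.32 log units; beyond the scatter). Compound 3 is therefore estimated at 6000 nM, within a range of 2000 nM to 16000 nM.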

Compound 3, half-maximal inhibitory concentration: 8700 nM
Estimate against measurement, compound 3: 1.5-fold (0.16 log units) below, within the range that was stated.
By their numbers in this assay, from the lowest: compounds 1, 3 and 2 (each within the scatter of the next).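

In this assay, chlorine now appears on the benzyl arm, and the swap from the difluorinated ring gives a 1.4-fold lower number from compound 2 to compound 3 (0.16 log units; within the scatter), while chloro in place of fluoro on an aromatic carbon gives a 1.3-fold higher number from compound 1 to compound 3 (0.13 log units; within the scatter). Both the kind of halogen and the change from 2,4-difluorophenyl to 3-chlorophenyl, on a saturated chain carbon bound to an amine nitrogen in a ring, therefore leave the number within the scatter, and all three compounds stand within the scatter of one another. Nothing measured here speaks to why these groups give such similar numbers.

On these data alone, all three compounds carry a halogen on a phenyl ring at this place, so it remains open whether an unsubstituted phenyl, a methoxyphenyl or a pyridine ring would move the number beyond the scatter. As far as these compounds go, a bromo or trifluoromethyl group on the ring also remains open.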